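Three Weak Antiproliferatives and a Fourth Still Untested

The source may hold more compounds than are shown below. What is called first, only, known or untested is meant among the compounds shown, and "the series" means these compounds.

Of the compounds shown here, three sharing one core have been tested in a functional assay on KYSE-410 cells (Homo sapiens) for antiproliferative activity, read by MTT assay, with a stated time of 72 h; on this read-out lower numbers stand for stronger inhibition and higher numbers for weaker inhibition. Compound 1 `CC(C)(C)c1ccc(NC(=O)c2cc(=O)[nH]c3cc(Br)ccc23)cc1` reaches only the limit of this assay, > 20000 nM, and gives no number. Compound 2 `O=C(Nc1cc(F)cc(F)c1)c1cc(=O)[nH]c2cc(F)ccc12` likewise stops at the limit, > 20000 nM. Compound 3 `O=C(Nc1cccc(F)c1)c1cc(=O)[nH]c2cc(-c3ccc(F)cc3)ccc12` is the only one of the three to give a number, 10300 nM. It therefore stands alone against the other two, which sit at the limit of > 20000 nM in this assay, at which 2 of the 3 values shown sit.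

Compound 4 `O=C(Nc1cccc(F)c1)c1cc(=O)[nH]c2cc(C3=CCOCC3)ccc12` has not been measured. It differs from compound 3 in one place: a group of 6 heavy atoms (5 carbon, 1 oxygen; one six-membered non-aromatic ring with 1 hetero atom) in place of a group of 7 heavy atoms (6 carbon, 1 fluorine; one six-membered aromatic ring of carbon only), on an aromatic carbon. Among the compounds with values here, no step between measured compounds in this assay has been recorded, so the size of this change can only be judged from how weak the whole group is. From compound 3 the expected step is a 1.5-fold higher number from compound 3 to compound 4 (0.16 log units; within the scatter), pointing, if anywhere, toward weaker inhibition. Compound 4 is therefore expected to give about 15000 nM in this assay, within a range from 5000 nM to 40000 nM, with a real chance that only the limit is reported.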

Compound 4, half-maximal inhibitory concentration: 12100 nM
Estimate against measurement, compound 4: 1.2-fold (0.09 log units) above; low and high end bracket the measured number.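

In this assay, within the data shown here, this aromatic carbon of the shared core gives the first step that can be read between two measured compounds: a 1.2-fold higher number from compound 3 to compound 4 (0.07 log units; within the scatter). Within this one pair, the 4-fluorophenyl group is not required for a measurable number, as a six-membered non-aromatic ring containing oxygen and a double bond serves equally well within the scatter. The pair still says little about strong inhibition, since the other values shown are limits rather than numbers: the limit of > 20000 nM in this assay, at which 2 of the 4 values shown sit.

The compounds shown leave open whether an amine or a carboxylic acid at this position would shift the number beyond the scatter. They also leave open whether a longer chain in place of the ring would keep a measurable number or fall back to the limit.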